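A few compounds are considered here, and "the series" means these few. Any claim that something is new, unique, unknown or untested is made for them only; others in the source may bear on it.

Compound 1 `CCCN(Cc1ccc(OCCN2C(=O)CCC2=O)c(C)c1)C(CC(=O)O)c1ccc(Cl)cc1` and compound 2 `CCCCN(Cc1ccc(OCCN2C(=O)CCC2=O)c(C)c1)C(CC(=O)O)c1ccc(Cl)cc1` share one core, while compound 3 `CCN(Cc1ccc(OCCn2c(=O)ccn(C)c2=O)c(C)c1)C(CC(=O)O)c1ccc(Cl)cc1` is built on another; the difference between the two cores is not broken down here. In a physicochemical assay for solubility, at pH 1.1 (on this read-out lower numbers stand for lower solubility and higher numbers for higher solubility), compound 1 gives 3000000 nM, compound 2 gives 3000000 nM and compound 3 gives 3000000 nM. The change from compound 1 to compound 2 is methyl in place of hydrogen on a saturated chain carbon, three bonds along the chain from an amine nitrogen, and in this assay it made no change at the digits printed from compound 1 to compound 2 (within the scatter). Compound 4 `CCCN(Cc1ccc(OCCn2c(=O)ccn(C)c2=O)c(C)c1)C(CC(=O)O)c1ccc(Cl)cc1` has not yet been measured in this assay. It is reached from compound 3 by methyl in place of hydrogen on a saturated chain carbon, two bonds along the chain from an amine nitrogen. Among the compounds with values here, this is the same kind of change as the one seen between compound 1 and compound 2, though not the same: in the measured pair the methyl enters three bonds along the chain from an amine nitrogen, whereas in the new pair it enters two bonds along the chain from an amine nitrogen. Because no change at the digits printed from compound 1 to compound 2 (within the scatter) stayed within the scatter, the step from compound 3 to compound 4 is expected to be no change at the digits printed from compound 3 to compound 4 (within the scatter). On that basis compound 4 is expected to give about 3000000 nM in this assay, within a range from 1500000 nM to 6000000 nM.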

Compound 4, solubility: 3000000 nM
Compound 4: the middle estimate sits on the measured number at the digits printed, and the stated range covers the measured number.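

In this assay the methyl added on the core of compound 3 made no change at the digits printed from compound 3 to compound 4 (within the scatter) on that core, matching the flat step no change at the digits printed from compound 1 to compound 2 (within the scatter) on the other core, and swapping the core while keeping the propyl chain made no change at the digits printed from compound 1 to compound 4 (within the scatter) in this comparison. So the flat result of adding a methyl carried over from one core to the other, but this rests on a single pair per core, with the methyl entering at different places on the chain, and on a single read-out. It does not show that such a change is without effect in general, and nothing measured here bears on why the values stay level.

The compounds shown leave open whether a longer chain such as hexyl, or an amine at the end of the propyl chain, would stay level with these four on either core. They also leave open whether an amide in place of the carboxylic acid would do the same.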